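This account rests on a few compounds, and the source may have more. Where it says the series, first, only, none or still open, it means among the compounds named here.

Values measured in a functional assay on CAL-51 cells (Homo sapiens) for antiproliferative activity, read by luminescence and CellTiter-Glo, with a stated time of 3 days (a lower number here means a stronger inhibitor, a higher number a weaker inhibitor), are:
- compound 1 `C[C@@H](Oc1cc(C(=O)N(C)C)ccc1Nc1nc(O[C@H]2CC[C@@](C)(O)CC2)c2c(Cl)c[nH]c2n1)C(F)(F)F` gives 10 nM
- compound 2 `COc1cc(C(=O)N(C)C)ccc1Nc1nc(OC2CCCC2)c2cc[nH]c2n1` gives 497 nM
- compound 3 `COc1cc(N2CCN(C(=O)CO)CC2)ccc1Nc1nc(O[C@H]2CCOC(C)(C)C2)c2cc[nH]c2n1` gives 37 nM

Compound 2 has the highest number of the three, so it is the weakest inhibitor among them, and compound 1 and compound 3 both lie below it by more than the usual scatter. Compound 4 `COc1cc(C(=O)N(C)C)ccc1Nc1nc(O[C@H]2CC[C@@](C)(O)CC2)c2cc[nH]c2n1` differs from compound 2 in one place, with 4-hydroxy-4-methylcyclohexyl in place of cyclopentyl on an oxygen on an aromatic ring. For the measured compounds named here, no two measured compounds differ in one place only, so the effect of this change has not been measured directly. Compound 1 carries the same 4-hydroxy-4-methylcyclohexyl group and gives 10 nM in this test, which points towards a lower number. It also differs from compound 4 elsewhere, so only part of that gap is expected to carry over. The expected change is a 4.5-fold lower number from compound 2 to compound 4 (0.65 log units; beyond the scatter) in this assay and is estimated to lie beyond the scatter. For compound 4 the estimated value is 110 nM within an expected range of 35 nM to 350 nM in this measurement.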

Compound 4, half-maximal inhibitory concentration: 44 nM
Beside the measured number, compound 4's estimate is 2.5-fold (0.40 log units) above it; the measured number falls inside the stated range.
By their numbers in this assay, from the lowest: compound 1; then compounds 3 and 4 (each within the scatter of the next); then compound 2.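

Putting 4-hydroxy-4-methylcyclohexyl in place of cyclopentyl on the oxygen gives an 11-fold lower number from compound 2 to compound 4 (1.05 log units; beyond the scatter) in this assay with nothing else in the molecule changed. For the compounds shown here, this is the first direct reading of this position: the earlier compounds differed from one another in several places at once, so none of them could show that the group on this oxygen can, on its own, move the number by more than the scatter. No measurement shown here explains why the step is this large.

The change alters the ring size and also adds both a hydroxyl and a methyl, so the compounds shown cannot separate the contribution of each part. As far as these compounds go, whether a plain cyclohexyl ring, or an amine in place of the hydroxyl, would give a similar number remains open.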